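This account rests on a few compounds, and the source may have more. Where it says the series, first, only, none or still open, it means among the compounds named here.

Going by the values given here, compound 2 `OCc1ccc(N2CCN(CC[C@@H](O)c3ccc(Cl)cc3)CC2)cc1Cl` gives the highest of the two numbers so far in an assay on CHO cells for binding affinity to D(4) dopamine receptor (Homo sapiens); a lower number here means a stronger inhibitor, a higher number a weaker inhibitor: compound 2 shows 81.4 nM, whereas compound 1 `OCc1ccc(N2CCN(CCC(O)c3ccc(Cl)cc3)CC2)cc1Cl`, the nearest neighbour, gives 11 nM. The step of a 7.4-fold higher number from compound 1 to compound 2 (0.87 log units; beyond the scatter) fits with the fact that one of compounds 1 and 2 is drawn with a defined configuration and the other without, at the place where they differ, since compound 1 is drawn without a configuration at that chain carbon. Compound 3 `OCc1ccc(N2CCN(CC[C@H](O)c3ccc(Cl)cc3)CC2)cc1Cl` differs from compound 2 by the two compounds have the same atoms and bonds and differ only in configuration as drawn: 1 of 1 stereo elements differ; a stereocentre at a saturated chain carbon is drawn R in compound 2 and S in compound 3. Among the compounds with values here, the only measured step that bears on this, a 7.4-fold higher number from compound 1 to compound 2 (0.87 log units; beyond the scatter), suggests that the undefined material of compound 1 owes its lower number to the configuration now drawn in compound 3. A drop is therefore expected, a 14-fold lower number from compound 2 to compound 3 (1.13 log units; beyond the scatter), and compound 3 is estimated at 6 nM with a range of 2.5 nM to 15 nM.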

Compound 3, inhibition constant: 8.6 nM
Beside the measured number, compound 3's estimate is 1.4-fold (0.16 log units) below it; low and high end bracket the measured number.
By their numbers in this assay, from the lowest: compounds 3 and 1 (each within the scatter of the next); then compound 2.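

At this chain carbon, the two drawn configurations can now be compared directly in this assay, giving a 9.5-fold lower number from compound 2 to compound 3 (0.98 log units; beyond the scatter). Nothing else changes across that step: the fact that compounds 2 and 3 differ only in the configuration as drawn. Drawing the centre as S gives no separation from the undefined material, with a 1.3-fold lower number from compound 1 to compound 3 (0.11 log units; within the scatter).

Still open, as far as these compounds go, is whether the same gap between R and S holds with an amine or a methyl ether in place of the hydroxyl at this carbon. A longer chain raises the same question.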